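The source may hold more compounds than are shown below. What is called first, only, known or untested is meant among the compounds shown, and "the series" means these compounds.

Of the compounds shown here, two have been tested so far in a functional assay (aorta) for inhibition, with Rattus norvegicus as the target; on this read-out higher numbers stand for weaker inhibition and lower numbers for stronger inhibition. Compound 1 `Cc1nsc(-c2ccc(N3CCN(c4cccc(C(F)(F)F)c4)CC3)nc2)n1` gives 5 nM, and compound 2 `FC(F)(F)c1cccc(N2CCN(c3ccc(-c4ncns4)nn3)CC2)c1` gives 70 nM. Compound 2 therefore holds the higher of the two numbers, which makes it the weaker inhibitor of the pair, and the gap lies beyond the usual scatter of repeat measurements. Compound 3 `CCc1nsc(-c2ccc(N3CCN(c4cccc(C(F)(F)F)c4)CC3)nn2)n1` is compound 2 changed in one place: ethyl in place of hydrogen on an aromatic carbon. Put simply, ethyl replaces hydrogen on an aromatic carbon, turning 1,2,4-thiadiazol-5-yl into 3-ethyl-1,2,4-thiadiazol-5-yl. Among the compounds with values here, no measured pair shows this change on its own, so any forecast is uncertain. Still, compound 1 at 5 nM shows that much lower numbers occur in this small set. A moderate move toward stronger inhibition is therefore expected, with an estimated 3.5-fold lower number from compound 2 to compound 3 (0.54 log units; beyond the scatter). The expected value for compound 3 is 20 nM, with an estimated range of 5 nM to 70 nM.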

Compound 3, half-maximal inhibitory concentration: 8 nM
Compound 3: middle estimate off by 2.5-fold (0.40 log units), on the high side; low and high end bracket the measured number.
By their numbers in this assay, from the lowest: compounds 1 and 3 (each within the scatter of the next); then compound 2.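

In this assay, within the data shown here, ethyl in place of hydrogen on this aromatic carbon gives an 8.8-fold lower number from compound 2 to compound 3 (0.94 log units; beyond the scatter), the first change in one place seen in this set, and the step lies beyond the scatter. This carbon, between two ring nitrogen atoms, is therefore a position where adding a group of just 2 carbon atoms goes with clearly stronger inhibition. Nothing available explains why the number falls.

The compounds shown leave open whether a longer chain such as propyl, or an amine on this same carbon, would strengthen inhibition further or lose the gain. They also leave open whether the gain carries over to other cores, as this single pair is all that speaks to the change.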